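Azetidine amide series: cyclobutyl replaces fluorophenyl on the carbonyl

The source may hold more compounds than are shown below. What is called first, only, known or untested is meant among the compounds shown, and "the series" means these compounds.

The series is read in an assay on HEK293 cells for positive allosteric modulation of metabotropic glutamate receptor 5 (Homo sapiens), read by FLIPR; a higher number here means that more compound is needed for the effect, a lower number that less compound is needed. Compound 1 `Cc1ccc(S(=O)(=O)N2CC(c3nc(-c4cccc(C)c4)no3)C2)cc1` gives only a limit, > 10000 nM. Compound 2 `O=C([C@H]1CC2CCC1C2)N1CC(c2nc(-c3cccc(F)c3)no2)C1` gives 72 nM. Compound 3 `O=C(c1cccc(F)c1)N1CC(c2nc(-c3cccc(Cl)c3)no2)C1` likewise gives only a limit, > 10000 nM, so it stands at the limit of > 10000 nM in this assay, at which 2 of the 3 values shown sit, together with compound 1, with no number of its own. Compound 4 `O=C(C1CCC1)N1CC(c2nc(-c3cccc(Cl)c3)no2)C1` differs from compound 3 by cyclobutyl in place of 3-fluorophenyl on a carbonyl carbon. Going by the values given here, no measured step between two compounds runs in this direction. Still, a gain beyond the scatter is expected for compound 4, with the step estimated as an at least 25-fold lower number from compound 3 to compound 4 (1.39 log units; beyond the scatter). The expectation rests on compound 2, which in this assay gives 72 nM. For compound 4 the estimate is 400 nM, within 60 nM to 4000 nM.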

Compound 4, half-maximal effective concentration: > 10000 nM
Compound 4 ended at the assay's limit; the forecaster's own chance of this, stated with the estimate: 25%; at least 25-fold (1.39 log units) between middle value and limit.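

Compound 3 and compound 4 both give only a limit, not a number, so no step between them can be read: the limit of > 10000 nM in this assay, at which 3 of the 4 values shown sit.

The compounds shown leave open whether cyclobutyl in place of 3-fluorophenyl on a carbonyl carbon changes the read-out at all.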